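The source may hold more compounds than are shown below. What is called first, only, known or untested is meant among the compounds shown, and "the series" means these compounds.

Series values in a functional assay on CCRF-CEM cells (Homo sapiens) for antiproliferative activity, with a stated time of 72 h; on this read-out higher numbers stand for weaker inhibition and lower numbers for stronger inhibition:

- Compound 1 `Cc1cccc(CNc2ncnc3c2ncn3[C@@H]2O[C@H](CO)[C@@H](O)[C@H]2O)c1`: 19100 nM.
- Compound 2 `Cc1ccc(CNc2ncnc3c2ncn3[C@@H]2O[C@H](CO)[C@@H](O)[C@H]2O)cc1`: > 166000 nM, a limit of the assay and not a number.
- Compound 3 `COc1cccc(CNc2ncnc3c2ncn3[C@@H]2O[C@H](CO)[C@@H](O)[C@H]2O)c1`: 7600 nM.

Compound 3 has the lower of the two actual numbers, and the nearest neighbour is compound 1, with a 2.5-fold lower number from compound 1 to compound 3 (0.40 log units; beyond the scatter).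

Compound 4 `OC[C@H]1O[C@@H](n2cnc3c(NCc4ccc(Cl)c(Cl)c4)ncnc32)[C@H](O)[C@@H]1O` carries 3,4-dichlorophenyl in place of 3-methoxyphenyl on a saturated chain carbon bound to a nitrogen on an aromatic ring. Among the measured compounds shown here, no chlorine-bearing compound has been measured, so the evidence is indirect. Exchanging methoxy for methyl gave only a modest step, the one already noted. Exchanging 3-methylphenyl for 4-methylphenyl gave an at least 8.6-fold higher number from compound 1 to compound 2 (0.93 log units; beyond the scatter), and the large at least 21-fold lower number from compound 2 to compound 3 (1.33 log units; beyond the scatter) shows how far this series can move with the phenyl substitution. On the strength of the step to compound 2, a move to a higher number is expected, though a limit remains possible. The expected change is a 3.9-fold higher number from compound 3 to compound 4 (0.60 log units; beyond the scatter). For compound 4 the estimate is 30000 nM, with an expected range from 6000 nM to 150000 nM.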

Compound 4, half-maximal inhibitory concentration: 3800 nM
Beside the measured number, compound 4's estimate is 7.9-fold (0.90 log units) above it; measured number outside the range, below it.
By their numbers in this assay, from the lowest: compounds 4 and 3 (each within the scatter of the next); then compound 1. At a limit, above all of these: compound 2.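

In this assay, 3,4-dichlorophenyl at this place, on a saturated chain carbon bound to a nitrogen on an aromatic ring, holds the level of 3-methoxyphenyl, with a 2.0-fold lower number from compound 3 to compound 4 (0.30 log units; within the scatter), and separates from 3-methylphenyl, with a 5.0-fold lower number from compound 1 to compound 4 (0.70 log units; beyond the scatter). The poor result of 4-methylphenyl therefore does not carry over to every group with a substituent numbered 4, as an at least 43-fold lower number from compound 2 to compound 4 (1.64 log units; beyond the scatter) shows. That step gives only a bound, since compound 2 stands at a limit and not a number: the limit of > 166000 nM in this assay, at which 1 of the 4 values shown sits.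

The compounds shown do not separate the contributions of the two chlorines, so 3-chlorophenyl and 4-chlorophenyl remain open as single changes. Also open, from the compounds shown here alone, is how this place responds to a carboxylic acid or an amine on the phenyl ring, or to a longer chain in place of the benzyl link.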